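This account rests on a few compounds, and the source may have more. Where it says the series, first, only, none or still open, it means among the compounds named here.

- Compound 1 `CCOC(=O)/C=C/c1ccc(NC(=O)C2(NC(=O)c3ccc4c(C5CCCC5)c(-c5ncc(Cl)cn5)n(C)c4c3)CCC2)cc1OCC`: > 5 h
- Compound 2 `CCOc1cc(NC(=O)C2(NC(=O)c3ccc4c(C5CCCC5)c(-c5ncc(Cl)cn5)n(C)c4c3)CCC2)ccc1/C=C/C(=O)OCC(C)C`: > 5 h
- Compound 3 `CCOc1cc(NC(=O)C2(NC(=O)c3ccc4c(C5CCCC5)c(-c5ncc(Cl)cn5)n(C)c4c3)CCC2)ccc1/C=C/C(=O)OCC(Cl)(Cl)Cl`: > 5 h

These three compounds were tested in an ADME assay (intestine, Homo sapiens) for pharmacokinetics, using microsomes (a higher number here means that the compound lasts longer, a lower number that the compound disappears faster), and each entry is a limit and not a number. Compound 2 therefore has no exact position, and the shared picture is the limit of > 5 h in this assay, at which 3 of the 3 values shown sit.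

Compound 4 `CCOc1cc(NC(=O)C2(NC(=O)c3ccc4c(C5CCCC5)c(-c5ncc(Cl)cn5)n(C)c4c3)CCC2)ccc1/C=C/C(=O)OCC(=O)N1CCOCC1` differs from compound 2 in one place: (morpholin-4-yl)carbonyl in place of isopropyl on a saturated chain carbon bound to an oxygen next to a carbonyl group. Put another way, isobutoxy gives way to ((morpholin-4-yl)carbonyl)methoxy.

Three measured steps change this same place: a step that the two limits leave unreadable from compound 1 to compound 2, a step that the two limits leave unreadable from compound 1 to compound 3 and a step that the two limits leave unreadable from compound 2 to compound 3. Both ends of each step are limits, and none has a size that can be read. For the measured compounds named here, no measured compound carries (morpholin-4-yl)carbonyl here, and the range must stay wide.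

Because the limit of > 5 h in this assay, at which 3 of the 3 values shown sit, applies to all three compounds, no step beyond the usual scatter is expected in this assay, in either direction. The estimated change is a step that the limit leaves unreadable from compound 2 to compound 4. The expected half-life for compound 4 is 6 h, within an estimated range of 2.5 h to 12 h.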

Compound 4, half-life: 3.42 h
For compound 4 the middle estimate is 1.8-fold (0.24 log units) above the measured one; low and high end bracket the measured number.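

For the compounds shown here, compound 4 gives 3.42 h in this assay, the only exact number at this place, on a saturated chain carbon bound to an oxygen next to a carbonyl group. The other compounds stop at a limit of the assay: the limit of > 5 h in this assay, at which 3 of the 4 values shown sit. Measured against those limits, the change reads as an at least 1.4-fold lower number from compound 2 to compound 4 (0.16 log units; that floor lies within the scatter), as an at least 1.4-fold lower number from compound 3 to compound 4 (0.16 log units; that floor lies within the scatter) and as an at least 1.4-fold lower number from compound 1 to compound 4 (0.16 log units; that floor lies within the scatter); each is only a floor, so the true change may be larger, but it is not shown to exceed the usual scatter.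

The steps among compound 1, compound 2 and compound 3 cannot be read, so these three cannot be ranked. As far as these compounds go, it remains open whether the morpholine ring or the carbonyl goes with the measured number, and how a simple amine, an open-chain amide or a carboxylic acid would behave at this place.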